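Shifting the Methoxy Group: From Compound 2 to Compound 3

The source may report more compounds than this note shows. Statements on the series, on what has been measured and on what is new or still open speak of the compounds shown alone.

Measured compounds:
compound 1 `O=c1cc(Cn2ccnc2)c2ccc(OCc3cccc(C(F)(F)F)c3)cc2o1` — 20 nM
compound 2 `COc1ccc(COc2ccc3c(Cn4ccnc4)cc(=O)oc3c2)cc1` — 80 nM

Of the compounds shown here, two have been measured in an assay on V79MZh11B1 cells for inhibition of cytochrome P450 11B1, mitochondrial (Homo sapiens), read by HPLC, with a stated time of 25 min; on this read-out lower numbers stand for stronger inhibition and higher numbers for weaker inhibition. Compound 1 `O=c1cc(Cn2ccnc2)c2ccc(OCc3cccc(C(F)(F)F)c3)cc2o1` gives 20 nM. Compound 2 `COc1ccc(COc2ccc3c(Cn4ccnc4)cc(=O)oc3c2)cc1` gives 80 nM, the higher of the two numbers; its gap to compound 1 lies beyond the usual scatter, so compound 2 is the weaker inhibitor of the pair. Compound 3 `COc1cccc(COc2ccc3c(Cn4ccnc4)cc(=O)oc3c2)c1` has not yet been measured. It differs from compound 2 in a single place: 3-methoxyphenyl in place of 4-methoxyphenyl on a saturated chain carbon bound to an oxygen on an aromatic ring. The two compounds are built from the same atoms, joined differently. For the measured compounds named here, no pair of measured compounds differs in exactly this way, so the measured numbers do not show how large such a step tends to be. A modest step is expected, more likely toward a lower number than a higher one, and it may well stay within the scatter. Compound 3 is estimated at 50 nM, with a range from 15 nM to 160 nM. The expected step is a 1.6-fold lower number from compound 2 to compound 3 (0.20 log units; within the scatter).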

Compound 3, half-maximal inhibitory concentration: 48 nM
For compound 3 the middle estimate is 1.0-fold (0.02 log units) above the measured one; low and high end bracket the measured number.
By their numbers in this assay, from the lowest: compound 1; then compounds 3 and 2 (each within the scatter of the next).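

In this assay, taking 3-methoxyphenyl in place of 4-methoxyphenyl on a saturated chain carbon bound to an oxygen on an aromatic ring gives a 1.7-fold lower number from compound 2 to compound 3 (0.22 log units; within the scatter) and so leaves the two compounds indistinguishable: for methoxy, this change of ring place has no effect that can be told from the scatter. Compound 3 also forms a one-place pair with compound 1, and methoxy in place of trifluoromethyl on an aromatic carbon gives a 2.4-fold higher number from compound 1 to compound 3 (0.38 log units; beyond the scatter) in this comparison, which is a real difference even though the step is modest. So, among these three compounds, a change in which group is present shows up clearly, while the one shift of methoxy tested does not. Nothing in the available data accounts for either step.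

Going by these compounds, whether moving trifluoromethyl around the ring would be as inconsequential as moving methoxy remains open, as trifluoromethyl appears in only one place here. Also open, on these data alone, is how other groups on that aromatic carbon, such as a nitrile, a chlorine or a hydroxyl, would compare with methoxy and trifluoromethyl.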